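Hydroxy to Methoxy: Expected Effect on Cell Growth Inhibition

The source may report more compounds than this note shows. Statements on the series, on what has been measured and on what is new or still open speak of the compounds shown alone.

Measured so far:
compound 1, `CC1(/C=C/c2ccccc2O)C=CC(=O)O1`, gives 57300 nM
compound 2, `CC1(/C=C/c2cccc(O)c2)C=CC(=O)O1`, gives 88100 nM
compound 3, `COc1ccccc1/C=C/C1(C)C=CC(=O)O1`, gives 30800 nM

These three numbers come from a functional assay on HaCaT cells (Homo sapiens) for inhibition, read by sulforhodamine B assay, with a stated time of 48 h; on this read-out lower numbers stand for stronger inhibition of growth and higher numbers for weaker inhibition of growth. Compound 3 differs from compound 1 by methyl in place of hydrogen on an oxygen on an aromatic ring, and this change gave a 1.9-fold lower number from compound 1 to compound 3 (0.27 log units; within the scatter). Compound 2 has the same atoms as compound 1 joined differently; the difference between the two cores is not broken down here, and their two values lie within the scatter of each other.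

Compound 4, `COc1cccc(/C=C/C2(C)C=CC(=O)O2)c1`, is not yet measured. Among the measured compounds shown here, it differs from compound 2 by methyl in place of hydrogen on an oxygen on an aromatic ring, the same change as the one from compound 1 to compound 3, at the same kind of place. In this assay, for the measured compounds named here, compound 4 is expected to show a 1.8-fold lower number from compound 2 to compound 4 (0.25 log units; within the scatter), a step of about the size seen before, because a 1.9-fold lower number from compound 1 to compound 3 (0.27 log units; within the scatter) is the only guide available. The estimate for compound 4 is 50000 nM, expected to fall between 25000 nM and 100000 nM.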

Compound 4, concentration for total growth inhibition: 5700 nM
The estimate for compound 4 lay 8.8-fold (0.94 log units) above the measured number; the measured number lies below the stated range.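

In this assay, the change from hydroxy to methoxy gave a 15-fold lower number from compound 2 to compound 4 (1.19 log units; beyond the scatter), a large step. The same change therefore did not carry over with a fixed size from one core to the other: the same change on two cores in this assay, a 1.9-fold lower number (0.27 log units; within the scatter) from compound 1 to compound 3 and a 15-fold lower number (1.19 log units; beyond the scatter) from compound 2 to compound 4, 8.3-fold (0.92 log units) apart, beyond the scatter of two such steps This shows that the size of the step depends on the core that carries it, at least for these two pairs, but two pairs give no rule for predicting the step on a further core and do not show what in the cores sets the size.

On these data alone, what an ethoxy group or an amine would do in place of the methoxy stays open. As far as these compounds go, it also remains unknown whether the large step belongs to methoxy alone or would appear with other groups on that oxygen.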